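Benzyl group variation at the piperazine and cytotoxicity

The source may report more compounds than this note shows. Statements on the series, on what has been measured and on what is new or still open speak of the compounds shown alone.

Measured so far in an ADME assay on MT4 cells (Homo sapiens) for cytotoxicity, read by MTT assay, with a stated time of 4 days; on this read-out higher numbers stand for lower toxicity in this test and lower numbers for higher toxicity in this test:
compound 1 `CCOC(=O)c1cnc(N2CCN(Cc3ccc(C#N)cc3)CC2)nc1Oc1c(C)cc(-c2ccc(C#N)cc2)cc1C` — > 125000 nM, a limit of the assay.
compound 2 `CCOC(=O)c1cnc(N2CCN(Cc3ccccc3C(F)(F)F)CC2)nc1Oc1c(C)cc(-c2ccc(C#N)cc2)cc1C` — > 125000 nM, a limit of the assay.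
compound 3 `CCOC(=O)c1cnc(N2CCN(Cc3cccc(F)c3)CC2)nc1Oc1c(C)cc(-c2ccc(C#N)cc2)cc1C` — > 125000 nM, a limit of the assay.

Compound 3 stands only at a limit in this assay; the value given for it is not a number. All three values sit at the same limit, as the limit of > 125000 nM in this assay, at which 3 of the 3 values shown sit, records. The steps a step that the two limits leave unreadable from compound 1 to compound 2, a step that the two limits leave unreadable from compound 1 to compound 3 and a step that the two limits leave unreadable from compound 2 to compound 3 therefore carry no readable size, and nothing about the direction of any exchange at this position can be drawn from them.

Compound 4 `CCOC(=O)c1cnc(N2CCN(Cc3ccc([N+](=O)[O-])cc3)CC2)nc1Oc1c(C)cc(-c2ccc(C#N)cc2)cc1C` carries the change (4-nitrophenyl in place of 3-fluorophenyl on a saturated chain carbon bound to an amine nitrogen in a ring). Each measured exchange of the group on the saturated chain carbon bound to the amine nitrogen in the ring left the read-out at the limit. For compound 4 no step beyond the scatter is expected in this assay. The expected step from compound 3 to compound 4 is a number no higher from compound 3 to compound 4 (the limit leaves the size open). Compound 4 is expected at 125000 nM, in the range 60000 nM to 250000 nM, and most likely reported again only as a limit.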

Compound 4, half-maximal cytotoxic concentration: > 125000 nM
Compound 4: no number, only a limit; the forecaster's own chance of this, stated with the estimate: 85%; the middle value sits exactly at the limit.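

Compound 4 gives > 125000 nM, a limit and not a number, so no step between it and compound 1, compound 2 or compound 3 can be read, because all four values stand at the same limit: the limit of > 125000 nM in this assay, at which 4 of the 4 values shown sit.

The compounds shown leave open whether these four groups differ at all in this assay, and at what concentration any of these compounds becomes cytotoxic.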